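A few compounds are considered here, and "the series" means these few. Any claim that something is new, unique, unknown or untested is made for them only; others in the source may bear on it.

Measured in an in vitro functional assay on cells for agonist activity at Bombesin receptor subtype-3 (Homo sapiens), read by luminescence and calcium flux; on this read-out lower numbers stand for an effect already at smaller amounts and higher numbers for an effect only at larger amounts of compound:
- compound 1 `COc1ccc(Cc2cnc(CCc3ccc(-c4ccccc4C(=O)O)cc3)[nH]2)cc1` gives 5360 nM
- compound 2 `CCC(C)(C)Cc1c[nH]c(CCc2ccc(-c3ccccc3C(=O)O)cc2)n1` gives 25 nM
- compound 3 `CCCCc1cnc(C(CC)Cc2ccc(-c3ccccc3C(=O)O)cc2)[nH]1` gives 2720 nM

Compound 1 carries the highest number of the three. Its separation from compound 3 is within the usual scatter, so no order between those two is claimed; its separation from compound 2 is far beyond the scatter. Compound 4 `CC(C)(C)CCc1cnc(CCc2ccc(-c3ccccc3C(=O)O)cc2)[nH]1` is not yet measured. Relative to compound 1 the change is neopentyl in place of 4-methoxyphenyl on a saturated chain carbon bound to an aromatic carbon. Among the compounds with values here, no directly comparable step among the measured compounds exists, so the size of the step rests on the contrast between compound 1 and compound 2, whose branched alkyl chain on the shared core gives 25 nM. Because compound 2 gives 25 nM, compound 4 is expected to land far lower than compound 1, a step of an 89-fold lower number from compound 1 to compound 4 (1.95 log units; beyond the scatter), with an estimate of 60 nM in the range 15 nM to 300 nM.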

Compound 4, half-maximal effective concentration: 39 nM
For compound 4 the middle estimate is 1.5-fold (0.19 log units) above the measured one; the range from low to high includes it.
By their numbers in this assay, from the lowest: compounds 2 and 4 (each within the scatter of the next); then compounds 3 and 1 (each within the scatter of the next).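

In this assay, neopentyl in place of 4-methoxyphenyl on a saturated chain carbon bound to an aromatic carbon gives a 140-fold lower number from compound 1 to compound 4 (2.14 log units; beyond the scatter) as a single change on the shared core. At this position a ring is therefore not required for a low number, since the entering neopentyl has none. No measurement at hand explains the size of this step.

Still open, as far as these compounds go, is whether the methoxy or the aromatic ring itself goes with the high number of compound 1, which an unsubstituted phenyl would address. Also open, from the compounds shown here alone, is whether a cyclohexyl ring or an amine on this chain would hold the low number.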